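The compounds below may be only part of what the source reports. "The series", "measured", "known", "first", "only" and "open" are said of these compounds alone.

Compound 1 `Cc1cccc(NC[C@@H]2CC3(CC3)CN2C(=O)c2nc(C)sc2-c2ccccc2)n1` gives 7.6 in a functional assay on HEK293 cells for antagonist activity at Orexin receptor type 2 (Homo sapiens), read by FLIPR and calcium flux; on this read-out lower numbers stand for lower potency and higher numbers for higher potency (the scale is a negative logarithm). Compound 2 `Cc1nc(C(=O)N2CC3(CC3)C[C@H]2CNc2cc(C(F)(F)F)ccn2)c(-c2ccccc2)s1` gives 8.5 in this assay. Compound 3 `Cc1ccnc(NC[C@@H]2CC3(CC3)CN2C(=O)c2nc(C)sc2-c2ccccc2)n1` gives 7 in this assay.

Compound 3 stands lowest of the three measured compounds: the steps of a number 0.60 log units lower from compound 1 to compound 3 (beyond the scatter) and a number 1.50 log units lower from compound 2 to compound 3 (beyond the scatter) both lie beyond the scatter. Compound 4 `Cc1cc(C)nc(NC[C@@H]2CC3(CC3)CN2C(=O)c2nc(C)sc2-c2ccccc2)n1` differs from compound 3 by a single small change, (methyl in place of hydrogen on an aromatic carbon), on the aromatic carbon next to the ring nitrogen of the six-membered ring with two nitrogens.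

The measured steps each exchange one whole ring for another on the amine nitrogen: a number 0.90 log units higher from compound 1 to compound 2 (beyond the scatter), a number 0.60 log units lower from compound 1 to compound 3 (beyond the scatter) and a number 1.50 log units lower from compound 2 to compound 3 (beyond the scatter). None of them adds a methyl to a ring that otherwise stays the same, so none bears directly on this change. Among the measured compounds shown here, with no comparable step to lean on, the expectation in this assay is a small step, likely within the scatter, with the direction uncertain. Compound 4 is estimated at 7.1, with a range of 6.5 to 7.7. The expected step is a number 0.10 log units higher from compound 3 to compound 4 (within the scatter).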

Compound 4, negative logarithm of the antagonist equilibrium constant: 8.6
The estimate for compound 4 lay 1.50 log units below the measured number, outside the stated range (above it).
By their numbers in this assay, from the lowest: compound 3; then compound 1; then compounds 2 and 4 (each within the scatter of the next).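

Going from 4-methylpyrimidin-2-yl to 4,6-dimethylpyrimidin-2-yl adds one carbon and gives a number 1.60 log units higher from compound 3 to compound 4 (beyond the scatter) in this assay, so this aromatic carbon next to the ring nitrogen is a place where a very small change counts for a great deal. The same ring also compares well with the two pyridine-based groups, with a number 1.00 log units higher from compound 1 to compound 4 (beyond the scatter) against 6-methylpyridin-2-yl and a number 0.10 log units higher from compound 2 to compound 4 (within the scatter) against 4-(trifluoromethyl)pyridin-2-yl, so a six-membered aromatic ring with 2 nitrogen can match the best group seen so far. Among the compounds shown here, nothing measured here explains why one methyl moves the number so far.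

On these data alone, it remains open whether the gain is particular to methyl or also appears with an ethyl, a methoxy or an amine on this carbon. The compounds shown also leave open whether a trifluoromethyl on this same ring would do as well as the methyl.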